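A Smaller Ring on the Shared Core: Compound 4

The compounds below may be only part of what the source reports. "The series", "measured", "known", "first", "only" and "open" are said of these compounds alone.

Among the compounds with values here, compound 1 `Cc1nc(C(NC(=O)C(=O)Nc2ccc(Cl)cc2)C2CCCCN2C)sc1CCO` is the only member of this set for which an ADME assay on MT2 cells (Homo sapiens) for cytotoxicity, read by XTT assay, with a stated time of 4 days (a lower number here means that less compound is tolerated, a higher number that more compound is tolerated), returned a number: compound 1 gives 88000 nM. Compound 2 `Cc1nc(C(NC(=O)C(=O)NC2CCCCCC2)C2CCCCN2)sc1CO` reached only a limit in this assay, namely > 90000 nM. Compound 3 `Cc1ccc(NC(=O)C(=O)NC(c2nc(C)c(CO)s2)C2CCCCN2)c(F)c1` likewise reached only a limit in this assay, namely > 109000 nM. Within the data shown here, the single step among the measured compounds, a step that the two limits leave unreadable from compound 2 to compound 3, therefore cannot be read in either direction, because both of its ends sit at a limit, the limit of > 90000 nM in this assay, at which 1 of the 3 values shown sits, and (the limit of > 109000 nM in this assay, at which 1 of the 3 values shown sits).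

Compound 4 `Cc1nc(C(NC(=O)C(=O)Nc2ccc(Cl)cc2)C2CCCN2)sc1CCO` differs from compound 1 in one place: pyrrolidin-2-yl in place of 1-methylpiperidin-2-yl on a saturated chain carbon bound to an amide-type nitrogen and an aromatic carbon. Among the measured compounds shown here, no measured step touches the saturated chain carbon bound to an amide-type nitrogen and an aromatic carbon, so nothing measured here bears on this change directly. For the measured compounds named here, what the three measured compounds do show is that all of them sit at the upper edge of what this assay reports, and compound 1 is the only one to give a number at all.

Compound 4 is therefore expected to stay close to compound 1, with an estimate of 90000 nM and a range from 40000 nM to 200000 nM. The expected step of a 1.0-fold higher number from compound 1 to compound 4 (0.01 log units; within the scatter) lies within the scatter, and it is quite possible that this assay again reports only a limit for compound 4.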

Compound 4, half-maximal cytotoxic concentration: 42000 nM
Estimate against measurement, compound 4: 2.1-fold (0.33 log units) above, and the stated range covers the measured number.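

In this assay, within the data shown here, the change gives a 2.1-fold lower number from compound 1 to compound 4 (0.32 log units; beyond the scatter), the first readable step in this set, and it shows that a modest shift beyond the scatter can arise on the saturated chain carbon bound to an amide-type nitrogen and an aromatic carbon. In this pair, the entering pyrrolidin-2-yl brings a five-membered ring in place of the six-membered ring of 1-methylpiperidin-2-yl, with 1 hydrogen-bond donor where the leaving group has 0, and less compound is tolerated; that pattern rests on this single pair alone. Nothing measured here gives a reason for the shift.

Ring size and the methyl group on the ring nitrogen change together in this step, so it remains open whether a 1-methylpyrrolidin-2-yl group on the core of compound 1 would stay close to compound 1 or to compound 4. The step joining compound 2 and compound 3 still cannot be read, both of its ends being limits of the assay, and neither compound connects to compound 4 through a single change.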